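Amide variation: from compound 3 to compound 4

This account rests on a few compounds, and the source may have more. Where it says the series, first, only, none or still open, it means among the compounds named here.

Measured compounds:
compound 1 `CCN(CC)CCNC(=O)c1ccc(C(CC)(CC)c2ccc(OCCC(O)(CC)CC)c(C)c2)n1CC` gives 2290 nM
compound 2 `C#CCCOC(=O)c1ccc(C(CC)(CC)c2ccc(OCCC(O)(CC)CC)c(C)c2)n1CC` gives only a limit, > 50000 nM
compound 3 `CCOc1ccc(NC(=O)c2ccc(C(CC)(CC)c3ccc(OCCC(O)(CC)CC)c(C)c3)n2CC)cc1` gives only a limit, > 50000 nM

For the measured compounds named here, in an ADME assay on L02 cells (Homo sapiens) for antiproliferative activity, read by MTT assay, with a stated time of 48 h (on this read-out lower numbers stand for stronger inhibition and higher numbers for weaker inhibition), compound 1 carries the only number among the three. Compound 3 sits at the limit of > 50000 nM in this assay, at which 2 of the 3 values shown sit, so its own place is known only as that limit. Compound 4 `CCn1c(C(=O)N(C)CCO)ccc1C(CC)(CC)c1ccc(OCCC(O)(CC)CC)c(C)c1` differs from compound 3 at the amide: (2-hydroxyethyl)(methyl)amino in place of (4-ethoxyphenyl)amino on a carbonyl carbon. Going by the values given here, the steps that bear on this position are an at least 21-fold higher number from compound 1 to compound 3 (1.33 log units; beyond the scatter) and a step that the two limits leave unreadable from compound 2 to compound 3. Compound 4 does not restore the (2-(diethylamino)ethyl)amino of compound 1. The step of an at least 1.6-fold lower number from compound 3 to compound 4 (0.22 log units; that floor lies within the scatter) is therefore expected to be small, with compound 4 remaining near the limit. The estimate for compound 4 is 30000 nM, with a range from 8000 nM to 60000 nM.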

Compound 4, half-maximal inhibitory concentration: 2050 nM
Compound 4: the middle estimate sits 15-fold (1.17 log units) above what was measured; measured number below the stated range.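

In this assay, (2-hydroxyethyl)(methyl)amino on the carbonyl carbon gives an at least 24-fold lower number from compound 3 to compound 4 (1.38 log units; beyond the scatter) and an at least 24-fold lower number from compound 2 to compound 4 (1.38 log units; beyond the scatter), so a measurable value at this position does not depend on the (2-(diethylamino)ethyl)amino of compound 1. Those two amides sit level, with a 1.1-fold lower number from compound 1 to compound 4 (0.05 log units; within the scatter). Compound 3 remains a limit, not a number: the limit of > 50000 nM in this assay, at which 2 of the 4 values shown sit.

Still open, from the compounds shown here alone, is whether the hydroxyl or the methyl on the amide nitrogen accounts for the step. A dimethylamino group or a (2-hydroxyethyl)amino group on the carbonyl carbon would separate the two.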